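Hydroxy to hydrogen on compound 1

A few compounds are considered here, and "the series" means these few. Any claim that something is new, unique, unknown or untested is made for them only; others in the source may bear on it.

- compound 1 (`COc1cc(O)c2c(c1O)C/C(C)=C\[C@@H](O)C[C@@]1(C)O[C@@H]1C2=O`): 21100 nM
- compound 2 (`COc1cc(O)c2c(c1O)C[C@]1(C)O[C@@H]1CC[C@@]1(C)O[C@@H]1C2=O`): 14200 nM
- compound 3 (`COc1cc(O)c2c(c1O)C/C(C)=C\CC[C@@]1(C)O[C@@H]1C2=O`): not yet measured

In a functional assay on SW480 cells (Homo sapiens) for cytotoxicity, read by MTT assay, with a stated time of 48 h (a higher number here means a weaker inhibitor, a lower number a stronger inhibitor), compound 1 (21100 nM) stands level with compound 2 (14200 nM), as the two values lie within the scatter of each other. Going by the values given here, both are the only numbers available for this series.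

Compound 3 differs from compound 1 by hydrogen in place of hydroxy on a saturated ring carbon. Among the compounds with values here, no measured pair shows what this change does, so the data offer no step size to carry over and no direction to argue. No step beyond the scatter is expected in this assay. The estimated step (a 1.2-fold lower number from compound 1 to compound 3 (0.07 log units; within the scatter)) stays within the scatter. For compound 3 the expected value is 18000 nM and the estimated range runs from 7000 nM to 45000 nM in this read-out.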

Compound 3, half-maximal inhibitory concentration: > 40000 nM
Compound 3 ended at the assay's limit; the forecaster's own chance of this, stated with the estimate: 10%; middle value at least 2.2-fold (0.34 log units) from the limit.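

Hydrogen in place of hydroxy on a saturated ring carbon now has its first reading in this assay, where the change gives an at least 1.8-fold higher number from compound 1 to compound 3 (0.27 log units; that floor lies within the scatter). For compound 3 the result is a limit of the assay, not a number: > 40000 nM. The floor of this step lies within the scatter, yet the change brought no gain at this position, and its true size stays unfixed because the reading stops at the assay's limit: the limit of > 40000 nM in this assay, at which 1 of the 3 values shown sits.

One pair ending at a limit cannot say how much the hydroxy contributes to the activity of compound 1. From the compounds shown here alone, whether an amine or a fluorine atom on the same saturated ring carbon would hold the value of compound 1 remains open.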